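From isopropyl to ethyl on compound 1

This account rests on a few compounds, and the source may have more. Where it says the series, first, only, none or still open, it means among the compounds named here.

In an ADME assay on a cell-free system (plasma, Macaca mulatta) for metabolic stability, read by LC-MS, with a stated time of 60 min, tested at 10 uM (on this read-out lower numbers stand for a less stable compound and higher numbers for a more stable compound), compound 1 (`CC(C)[C@H](N)C(=O)N[C@@H](CCC(=O)C=[N+]=[N-])C(=O)OCc1c[nH]c2ccccc12`) gives 10%. Compound 2 (`CC(C)OC(=O)[C@H](CCC(=O)C=[N+]=[N-])NC(=O)OCOC(=O)C(C)(C)C`) gives 0%, which lies within the usual scatter of compound 1. Within the data shown here, the two compounds differ in more than one place, so no measured single-change step is available as a guide. Compound 3 (`CC[C@H](N)C(=O)N[C@@H](CCC(=O)C=[N+]=[N-])C(=O)OCc1c[nH]c2ccccc12`) differs from compound 1 by hydrogen in place of methyl on a saturated chain carbon bound to two saturated chain carbons, turning isopropyl to ethyl. The step of a number 3 percentage points lower from compound 1 to compound 3 (within the scatter) is expected to stay within the scatter, with no clear direction. Compound 3 is estimated at 7%, with an expected range of 0% to 20%.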

Compound 3, percent of the compound remaining: 4%
The estimate for compound 3 lay 3 percentage points above the measured number, and the stated range covers the measured number.
By their numbers in this assay, from the lowest: compounds 2, 3 and 1 (each within the scatter of the next).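

Among these compounds, replacing isopropyl with ethyl gives a number 6 percentage points lower from compound 1 to compound 3 (within the scatter) in this assay and provides the only single-change step. At this position, on a saturated chain carbon bound to two saturated chain carbons, removing this one methyl therefore gives no readable change in percent remaining. No available evidence bears on the reason for this result.
A longer chain or a hydroxyl group at this position remains untested in the compounds shown. From the compounds shown here alone, whether either would move the number beyond the usual scatter stays open.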